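Benzylsulfonyl in Place of a Thioether: Cytotoxicity Outlook

The compounds below may be only part of what the source reports. "The series", "measured", "known", "first", "only" and "open" are said of these compounds alone.

Compound 1 `COC(=O)N[C@@H](CSC(C)(C)C)C(=O)N1CCC[C@H]1c1ncc(-c2ccc(-c3ccc(-c4cnc([C@@H]5CCCN5C(=O)[C@@H](NC(=O)OC)C(C)C)[nH]4)cc3)cc2)[nH]1`: 10000 nM
Compound 2 `COC(=O)N[C@@H](CCSC)C(=O)N1CCC[C@H]1c1ncc(-c2ccc(-c3ccc(-c4cnc([C@@H]5CCCN5C(=O)[C@@H](NC(=O)OC)C(C)C)[nH]4)cc3)cc2)[nH]1`: 11000 nM

In an ADME assay on CCRF-CEM cells (Homo sapiens) for cytotoxicity (on this read-out higher numbers stand for lower toxicity in this test and lower numbers for higher toxicity in this test), compound 1 gives 10000 nM and compound 2 gives 11000 nM; the two numbers sit within the scatter of each other, as the step of a 1.1-fold higher number from compound 1 to compound 2 (0.04 log units; within the scatter) shows. Compound 3 `COC(=O)N[C@@H](CS(=O)(=O)Cc1ccccc1)C(=O)N1CCC[C@H]1c1ncc(-c2ccc(-c3ccc(-c4cnc([C@@H]5CCCN5C(=O)[C@@H](NC(=O)OC)C(C)C)[nH]4)cc3)cc2)[nH]1` is not yet measured. It carries benzylsulfonyl in place of (methylsulfanyl)methyl on a saturated chain carbon, two bonds along the chain from an amide-type nitrogen and a carbonyl carbon. Going by the values given here, only one measured step touches this position, and it stayed within the scatter, but the entering group is much larger than the one it replaces, so that single step is a weak guide. No shift beyond the scatter is expected, and the estimated step is a 1.1-fold lower number from compound 2 to compound 3 (0.04 log units; within the scatter). Compound 3 is therefore expected at 10000 nM, within 4000 nM to 25000 nM.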

Compound 3, half-maximal cytotoxic concentration: > 100000 nM
Compound 3: a limit, no number; the forecaster's own chance of this, stated with the estimate: 20%; middle value at least 10-fold (1.00 log units) from the limit.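

Benzylsulfonyl on this saturated chain carbon gives an at least 9.0-fold higher number from compound 2 to compound 3 (0.95 log units; beyond the scatter), and in place of (tert-butyl)sulfanyl it gives an at least 10-fold higher number from compound 1 to compound 3 (1.00 log units; beyond the scatter), so a change at this position can move this assay beyond the scatter, which the earlier step did not show. Compound 3 reads > 100000 nM, which is a limit of the assay and not a number. Both steps therefore give only a lower bound on the size of the shift: the limit of > 100000 nM in this assay, at which 1 of the 3 values shown sits.

The compounds shown leave open whether the shift goes with the sulfonyl or with the benzyl part. A methylsulfonyl group and a benzylsulfanyl group, which would separate the two, are not among them.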